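The compounds below may be only part of what the source reports. "The series", "measured", "known", "first", "only" and "open" are said of these compounds alone.

Working notes on the amide series built on the shared core of compound 1 `COc1ccc(C(=O)Nc2cccc(-c3oc4cc(-c5ccc(F)cc5)ccc4c(=O)c3O)c2)cc1`. In a functional assay on HepG2 cells (Homo sapiens) for antiproliferative activity, read by CCK-8 assay, with a stated time of 72 h (on this read-out lower numbers stand for stronger inhibition and higher numbers for weaker inhibition), compound 1 gives 8420 nM. Compound 2 `COc1cccc(C(=O)Nc2cccc(-c3oc4cc(-c5ccc(F)cc5)ccc4c(=O)c3O)c2)c1` gives 9950 nM in this assay, and compound 3 `O=C(Nc1cccc(-c2oc3cc(-c4ccc(F)cc4)ccc3c(=O)c2O)c1)c1cccc(F)c1` gives 15500 nM; both sit within the scatter of compound 1, so the three numbers cannot be told apart. The recorded steps confirm this: a 1.2-fold higher number from compound 1 to compound 2 (0.07 log units; within the scatter), a 1.8-fold higher number from compound 1 to compound 3 (0.27 log units; within the scatter) and a 1.6-fold higher number from compound 2 to compound 3 (0.19 log units; within the scatter) all stay inside the usual spread.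

Compound 4 `CCCc1ccc(C(=O)Nc2cccc(-c3oc4cc(-c5ccc(F)cc5)ccc4c(=O)c3O)c2)cc1` is the next member to be tested. Relative to compound 1 the change is propyl in place of methoxy on an aromatic carbon. Among the compounds with values here, none of the measured steps touches a propyl group; the nearest precedents are the exchanges of the methoxy in compound 1 for a 3-methoxyphenyl or a 3-fluorophenyl, and both left this assay unchanged beyond the scatter. Within the data shown here, no step is therefore expected in this assay from compound 1 to compound 4 beyond the scatter, and the estimate for compound 4 is 9000 nM, with a range of 4000 nM to 20000 nM, corresponding to an expected 1.1-fold higher number from compound 1 to compound 4 (0.03 log units; within the scatter).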

Compound 4, half-maximal inhibitory concentration: 51500 nM
For compound 4 the middle estimate is 5.7-fold (0.76 log units) below the measured one; measured number outside the range, above it.
By their numbers in this assay, from the lowest: compounds 1, 2 and 3 (each within the scatter of the next); then compound 4.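

In this assay, within the data shown here, the aromatic carbon para to a large group is the first place where a change registers: a 6.1-fold higher number from compound 1 to compound 4 (0.79 log units; beyond the scatter) lies beyond the scatter, whereas the steps among the three earlier amides all stayed inside it. The same separation appears against the two amides that differ from compound 4 in the whole aryl group, with a 5.2-fold higher number from compound 2 to compound 4 (0.71 log units; beyond the scatter) and a 3.3-fold higher number from compound 3 to compound 4 (0.52 log units; beyond the scatter) also beyond the scatter, so compound 4 stands apart from three compounds that cannot be told apart. The data at hand offer no measurement that explains why propyl in place of methoxy gives this step.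

With a single alkyl chain at this carbon, the compounds shown leave open whether the step follows the chain itself or the loss of the methoxy. A methyl, an ethoxy, a butyl chain or an amine on the same carbon would separate these readings.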